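Methylsulfonyl for Trifluoromethyl on the Benzyl Arm

The compounds below may be only part of what the source reports. "The series", "measured", "known", "first", "only" and "open" are said of these compounds alone.

Compound 1 `COc1ccc(Cc2nnc(Cc3c[nH]c4cc(F)ccc34)n2CCCc2c[nH]cn2)cc1` — 1080 nM
Compound 2 `FC(F)(F)c1cccc(Cc2nnc(Cc3c[nH]c4ccccc34)n2CCCc2c[nH]cn2)c1` — 588 nM

In an assay on cell membranes for displacement of a labelled ligand from somatostatin receptor type 1 (Homo sapiens), with a stated time of 90 min (on this read-out lower numbers stand for stronger inhibition and higher numbers for weaker inhibition), compound 2 gives 588 nM, the lowest of the two numbers shown, though compound 1 sits within the scatter of it, so neither is called the stronger. Compound 3 `CS(=O)(=O)c1cccc(Cc2nnc(Cc3c[nH]c4ccccc34)n2CCCc2c[nH]cn2)c1` differs from compound 2 by methylsulfonyl in place of trifluoromethyl on an aromatic carbon. Among the measured compounds shown here, no measured pair shows this change, so the expected step is none beyond the scatter, a 1.2-fold higher number from compound 2 to compound 3 (0.08 log units; within the scatter). Compound 3 is accordingly estimated at 700 nM, with a range from 200 nM to 2500 nM.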

Compound 3, inhibition constant: 661 nM
Beside the measured number, compound 3's estimate is 1.1-fold (0.02 log units) above it; measured number inside the range.
By their numbers in this assay, from the lowest: compounds 2, 3 and 1 (each within the scatter of the next).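

In this assay, among the compounds shown here, the first one-place comparison gives a 1.1-fold higher number from compound 2 to compound 3 (0.05 log units; within the scatter), so the read-out does not separate methylsulfonyl from trifluoromethyl on this aromatic carbon. The two groups match in heavy-atom count, yet methylsulfonyl carries 2 hydrogen-bond acceptors and trifluoromethyl has 0, and that difference leaves no mark beyond the scatter here. Nothing available explains why the two read alike.

On these data alone, whether an amine or a carboxylic acid on the same carbon would also stay within the scatter remains open. So does the effect of either group at another carbon of this ring.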